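The compounds below may be only part of what the source reports. "The series", "measured", "known", "first", "only" and "open" are said of these compounds alone.

Working notes on the series. Compound 1 `O=C(Nc1ccccc1)c1cnc(NCc2c(F)ccc3c2CCO3)n2cnnc12` was run in an ADME assay on microsomes from liver (Homo sapiens) for metabolic stability, read by LC-MS, using NADPH, with stated times of 5 min and 30 min, tested at 1 uM (a lower number here means slower removal, a higher number faster removal of the compound), and gave 14 mL.min-1.g-1. Going by the values given here, of the three numbers so far it is the smallest, but compound 3 `CNC(=O)c1ncc(-c2cnc(NCc3c(F)ccc4c3CCO4)c3cn[nH]c(=O)c23)n1C`, with 24 mL.min-1.g-1 in this assay, sits within the usual scatter of it; only compound 2 `CN(C)Cc1ccc2c(c1)CN(c1cnc(NCc3c(F)ccc4c3CCO4)c3cn[nH]c(=O)c13)C2=O`, at 32 mL.min-1.g-1 in this assay, lies beyond it. Among the compounds with values here, no pair of measured compounds differs in a single place, so no step has been measured in this assay.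

Compound 4 `C[C@H]1CC(=O)N(c2cnc(NCc3c(F)ccc4c3CCO4)n3cnnc23)C1` has not been measured. It differs from compound 1 thus: 4-methyl-2-oxopyrrolidin-1-yl in place of phenylcarbamoyl on an aromatic carbon. Within the data shown here, the change from compound 1 to compound 4 is expected to give no step in this assay beyond the scatter, perhaps slightly lower, as a 1.3-fold lower number from compound 1 to compound 4 (0.10 log units; within the scatter). For compound 4 in this assay the estimate is 11 mL.min-1.g-1, ranging from 5 mL.min-1.g-1 to 25 mL.min-1.g-1.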

Compound 4, intrinsic clearance in microsomes: < 3 mL.min-1.g-1
Compound 4: a limit, no number (the forecaster's own chance of this, stated with the estimate: 10%); middle value at least 3.6-fold (0.56 log units) from the limit.
By their numbers in this assay, from the lowest: compounds 1, 3 and 2 (each within the scatter of the next, the first and the last beyond it). At a limit, below all of these: compound 4.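

Going by these compounds alone, the first readable step at this position is a large one: 4-methyl-2-oxopyrrolidin-1-yl in place of phenylcarbamoyl gives an at least 4.6-fold lower number from compound 1 to compound 4 (0.66 log units; beyond the scatter) in this assay. Within the data shown here, the group on this aromatic carbon therefore counts for removal in this assay, which the earlier compounds, with no single-place pair, could not show. Compound 4 stands at a limit of the assay, not a number, so the step is only a bound: the limit of < 3 mL.min-1.g-1 in this assay, at which 1 of the 4 values shown sits.

Which part of the exchanged group carries the step stays open. So does the standing of a 2-oxopyrrolidin-1-yl without the methyl, or of a simple amine, on this carbon.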